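The source may report more compounds than this note shows. Statements on the series, on what has been measured and on what is new or still open speak of the compounds shown alone.

Measured in a functional assay on SK-BR-3 cells (Homo sapiens) for antiproliferative activity; on this read-out higher numbers stand for weaker inhibition and lower numbers for stronger inhibition:
compound 1 `CC(C)=CCc1cc(C(=O)Nc2cc3ccc(OCC4CCCN(C)C4)c(C)c3oc2=O)ccc1O`: 1300 nM
compound 2 `CC(C)=CCc1cc(C(=O)Nc2cc3ccc(OCCCN(C)C(C)C)c(C)c3oc2=O)ccc1O`: 570 nM
compound 3 `CC(C)=CCc1cc(C(=O)Nc2cc3ccc(OCCCN(C(C)C)C(C)C)c(C)c3oc2=O)ccc1O`: 1600 nM

Compound 3 lies within the scatter of compound 1, with a 1.2-fold higher number from compound 1 to compound 3 (0.09 log units; within the scatter). Only compound 2 stands clearly apart from it. Compound 4 `CC(C)=CCc1cc(C(=O)Nc2cc3ccc(OCCCN(C)C4CCCCC4)c(C)c3oc2=O)ccc1O` has not yet been measured. It differs from compound 3 by cyclohexyl(methyl)amino in place of diisopropylamino on a saturated chain carbon, three bonds along the chain from an oxygen on an aromatic ring. Put simply, cyclohexyl(methyl)amino stands in place of diisopropylamino, three bonds along the chain from an oxygen on an aromatic ring.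

The most relevant evidence is the modest change seen when isopropyl replaces methyl on an amine nitrogen, a 2.8-fold higher number from compound 2 to compound 3 (0.45 log units; beyond the scatter). Compound 4 carries a methyl on that nitrogen, which points towards a lower number than that of compound 3. Among the compounds with values here, no measured compound carries a cyclohexyl group, however. Within the data shown here, the one measured compound with a ring in this side chain, compound 1, does not support a large gain, given a 2.3-fold lower number from compound 1 to compound 2 (0.36 log units; beyond the scatter). The expected change is therefore small and downward, an estimated 1.8-fold lower number from compound 3 to compound 4 (0.25 log units; within the scatter). For compound 4 the estimated value is 900 nM, with an expected range from 400 nM to 2000 nM.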

Compound 4, half-maximal inhibitory concentration: 970 nM
Compound 4: middle estimate off by 1.1-fold (0.03 log units), on the low side; low and high end bracket the measured number.
By their numbers in this assay, from the lowest: compounds 2, 4, 1 and 3 (each within the scatter of the next, the first and the last beyond it).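

In this assay, putting cyclohexyl(methyl)amino in place of diisopropylamino, three bonds along the chain from an oxygen on an aromatic ring, gives a 1.6-fold lower number from compound 3 to compound 4 (0.22 log units; within the scatter). The other two new comparisons, a 1.7-fold higher number from compound 2 to compound 4 (0.23 log units; within the scatter) and a 1.3-fold lower number from compound 1 to compound 4 (0.13 log units; within the scatter), are also within the scatter, so the new compound cannot be separated from any of the three earlier ones, even though the earlier pair printed as a 2.8-fold higher number from compound 2 to compound 3 (0.45 log units; beyond the scatter) lies beyond the scatter. This position therefore accepts a six-membered non-aromatic ring of carbon only on the amine nitrogen without a change that stands clear of the scatter, which the earlier compounds could not show, but no measurement is at hand that would explain this result.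

The compounds shown leave open whether a smaller ring such as cyclopentyl, or an aromatic group such as benzyl on the same nitrogen, would stay within this narrow span of values. They also leave open how a piperidine or morpholine with the nitrogen inside the ring, or a longer chain between that nitrogen and the oxygen, would read in this assay.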